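Compound 1 to compound 4: a methoxy replacement

The source may hold more compounds than are shown below. What is called first, only, known or untested is meant among the compounds shown, and "the series" means these compounds.

Compound 1 `CC1=CCC[C@](C)(CC/C(C)=C/CC2=C(O)C(=O)C=C(N[C@@H](C(=O)O)[C@@H](C)O)C2=O)[C@@H]1C` gives > 10 ug/mL in an ADME assay on KB cells (Homo sapiens) for cytotoxicity, with a stated time of 48 h (on this read-out higher numbers stand for weaker inhibition and lower numbers for stronger inhibition), a limit and not a number. Compound 2 `C=C1[C@H](C)CCC[C@]1(C)CC/C(C)=C/CC1=C(O)C(=O)C=C(N[C@@H](C(=O)O)[C@H](C)O)C1=O` gives > 10 ug/mL in this assay, also a limit. Compound 3 `C=C1[C@H](C)CCC[C@]1(C)CC/C(C)=C/CC1=C(O)C(=O)C=C(N[C@@H](C(=O)O)[C@@H](C)O)C1=O` gives > 10 ug/mL in this assay, again a limit. Going by the values given here, the series so far therefore stands at the limit of > 10 ug/mL in this assay, at which 3 of the 3 values shown sit, and no rank order can be read from it.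

Compound 4 `COC1=CC(=O)C(O)=C(C/C=C(\C)CC[C@@]2(C)CCC=C(C)[C@H]2C)C1=O` departs from compound 1 by methoxy in place of (1-carboxy-2-hydroxypropyl)amino on a double-bonded ring carbon.

Two measured steps exist, and neither has a readable size. Among the compounds with values here, the first is a step that the two limits leave unreadable from compound 1 to compound 3, a swap of one group for another on a saturated chain carbon. The second is a step that the two limits leave unreadable from compound 2 to compound 3, which reflects (the fact that compounds 2 and 3 differ only in the configuration as drawn). Compounds 1, 2 and 3 all keep (1-carboxy-2-hydroxypropyl)amino, so neither step shows what its removal does.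

The expectation of stronger inhibition rests only on the structural change and on compound 1, whose > 10 ug/mL is a limit. The expected change is an at least 2.0-fold lower number from compound 1 to compound 4 (0.30 log units; that floor lies within the scatter), a loosely estimated size that may still end at the limit. For compound 4 the estimate is 5 ug/mL, with an expected range of 1.5 ug/mL to 20 ug/mL.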

Compound 4, half-maximal inhibitory concentration: > 10 ug/mL
Compound 4: only a limit was reported; the forecaster's own chance of this, stated with the estimate: 25%; middle value at least 2.0-fold (0.30 log units) from the limit.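

Compound 4 ends at a limit in this assay, as compound 1 does, so no new step can be read between compound 1 and compound 4: the limit of > 10 ug/mL in this assay, at which 4 of the 4 values shown sit.

The compounds shown leave open how strongly any of them inhibits, and whether methoxy in place of (1-carboxy-2-hydroxypropyl)amino changes the read-out at all.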